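Sulfonyl in Place of Methyl on a Ring Amine Nitrogen

The compounds below may be only part of what the source reports. "The series", "measured", "known", "first", "only" and "open" are said of these compounds alone.

Three compounds sharing one core were tested in an in vitro functional assay on RBL cells for antagonist activity at C-C chemokine receptor type 8 (Homo sapiens), read by FLIPR and calcium flux; a lower number here means a stronger inhibitor, a higher number a weaker inhibitor. Compound 1 `COc1ccc2nccc(C3CN(CC4CCN(Cc5cc6ccccc6[nH]5)CC4)C(=O)O3)c2c1` returns in this assay only a limit, < 50200 nM. Compound 2 `COc1ccc2nccc(C3CN(CC4CCCN(Cc5cc6ccccc6[nH]5)C4)C(=O)O3)c2c1` likewise gives a limit in this assay, < 50200 nM. Within the data shown here, compound 3 `COc1ccc2nccc(C3CN(C4CCN(C)CC4)C(=O)O3)c2c1` also stands at a limit in this assay, < 50200 nM. the limit of < 50200 nM in this assay, at which 3 of the 3 values shown sit, is all the record offers, so no step between measured compounds can be sized, and compound 3 cannot be placed against the others. Compound 4 `COc1ccc2nccc(C3CN(C4CCN(S(=O)(=O)c5ccc(Cl)c(Cl)c5)CC4)C(=O)O3)c2c1` differs from compound 3 in one place: (3,4-dichlorophenyl)sulfonyl in place of methyl on an amine nitrogen in a ring. Among the measured compounds shown here, with no measured step to guide the direction, the expected step that the limit leaves unreadable from compound 3 to compound 4 rests on the change alone and may not exceed the scatter. Compound 4 is estimated at 3000 nM, within a range from 300 nM to 30000 nM.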

Compound 4, half-maximal inhibitory concentration: < 50200 nM
Compound 4 was reported as a limit; the forecaster's own chance of this, stated with the estimate: 30%; the middle value is on the limit's open side.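

The step from compound 3 to compound 4 cannot be read, because both compounds stand only at a limit: the limit of < 50200 nM in this assay, at which 4 of the 4 values shown sit.

The compounds shown leave open whether (3,4-dichlorophenyl)sulfonyl in place of methyl changes inhibition at all, and by how much.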